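The source may hold more compounds than are shown below. What is called first, only, known or untested is meant among the compounds shown, and "the series" means these compounds.

In an assay for inhibition of transient receptor potential cation channel subfamily V member 1 (Rattus norvegicus), with a stated time of 10 min (a lower number here means a stronger inhibitor, a higher number a weaker inhibitor), compound 1 `CCCc1ccc(C/N=C(\S)NCc2ccc(NS(C)(=O)=O)c(F)c2)cc1` gives 460 nM. Compound 2 `CCOC(=O)Nc1ccc(C/N=C(\S)NCc2ccc(C(C)(C)C)cc2)cc1F` stands differently: in this assay compound 2 reaches only the limit of > 30000 nM, not a number, which is the limit of > 30000 nM in this assay, at which 1 of the 2 values shown sits. Compound 3 `COC(=O)CNc1ccc(C/N=C(\S)NCc2ccc(C(C)(C)C)cc2)cc1F` carries (methoxycarbonyl)methyl in place of ethoxycarbonyl on a nitrogen on an aromatic ring. Within the data shown here, no measured pair differs in this way, so the change itself offers no guide, and the expected step from compound 2 to compound 3 is a step that the limit leaves unreadable from compound 2 to compound 3, no movement beyond the scatter in either direction. Compound 3 is therefore estimated at 40000 nM in this assay, within a range from 8000 nM to 200000 nM, most likely again as a limit rather than a number.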

Compound 3, half-maximal inhibitory concentration: 3600 nM
For compound 3 the middle estimate is 11-fold (1.05 log units) above the measured one, outside the stated range (below it).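

In this assay, the group on this nitrogen clearly matters: putting (methoxycarbonyl)methyl in place of ethoxycarbonyl, with the same atoms joined differently, gives an at least 8.3-fold lower number from compound 2 to compound 3 (0.92 log units; beyond the scatter). The true size of this step remains unknown, and it can only be read as a minimum: the limit of > 30000 nM in this assay, at which 1 of the 3 values shown sits.

The compounds shown cannot separate the effect of the extra carbon between the nitrogen and the carbonyl from that of the shorter end chain. As far as these compounds go, how a carboxylic acid or a longer chain in the same place would compare also remains open.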